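Removing the chloro from compound 2

This account rests on a few compounds, and the source may have more. Where it says the series, first, only, none or still open, it means among the compounds named here.

In a functional assay on T47D cells (Homo sapiens) for inhibition, read by CCK-8 assay, with a stated time of 72 h, tested at 1 uM (on this read-out lower numbers stand for less inhibition of growth and higher numbers for more inhibition of growth at the one concentration tested), compound 1 (`CN(C)C(=O)c1cc2cnc(Nc3ccc(NC(=O)C4(C(=O)Nc5cccc(O)c5)CC4)cc3)nc2n1C1CCCC1`) gives 80.7% and compound 2 (`CN(C)C(=O)c1cc2cnc(Nc3ccc(NC(=O)C4(C(=O)Nc5ccc(Cl)c(C(F)(F)F)c5)CC4)cc3)nc2n1C1CCCC1`) gives 6.9% as the lower of the two numbers at hand. Compound 3 (`CN(C)C(=O)c1cc2cnc(Nc3ccc(NC(=O)C4(C(=O)Nc5cccc(C(F)(F)F)c5)CC4)cc3)nc2n1C1CCCC1`) departs from compound 2 at one place (hydrogen in place of chloro on an aromatic carbon), with hydrogen in place of chloro on an aromatic carbon, ortho to a trifluoromethyl group and para to a large group.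

Going by the values given here, only one measured step bears on this change, and it is a large one (a number 73.8 percentage points lower from compound 1 to compound 2 (beyond the scatter)), bringing in 4-chloro-3-(trifluoromethyl)phenyl in place of 3-hydroxyphenyl. That step swaps the whole substitution of the group, so it does not show what the chloro does alone. Compound 3 keeps the trifluoromethyl group of compound 2 at 6.9% and lacks the hydroxy group of compound 1 at 80.7% so only part of the large step is expected to return. The expected change is moderate and upward (a number 18.1 percentage points higher from compound 2 to compound 3 (beyond the scatter)). Compound 3 is estimated at 25% with 5% to 60% as the expected range.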

Compound 3, percent growth inhibition at one concentration: 9.7%
Estimate against measurement, compound 3: 15.3 percentage points above; the range from low to high includes it.
By their numbers in this assay, from the lowest: compounds 2 and 3 (each within the scatter of the next); then compound 1.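

In this assay, the step from chloro to hydrogen reads as a number 2.8 percentage points higher from compound 2 to compound 3 (within the scatter) and so does not separate the two compounds: with the trifluoromethyl group in place, the chloro on this aromatic carbon makes no difference that can be read. Going by these compounds alone, with the chloro set aside, the single exchange of trifluoromethyl in place of hydroxy gives a number 71 percentage points lower from compound 1 to compound 3 (beyond the scatter) as its step. The large drop first seen across the whole substitution, a number 73.8 percentage points lower from compound 1 to compound 2 (beyond the scatter) as its step, can therefore be placed almost entirely on that exchange and not on the chloro. Nothing in hand explains why this exchange matters so much on this read-out.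

As far as these compounds go, what the hydroxy group itself contributes remains open, since only a trifluoromethyl group stands against it on that carbon, and a methoxy group, an amine or a carboxylic acid there would show how narrow the requirement is. From the compounds shown here alone, it is also open whether the chloro would be equally without effect in a compound that keeps the hydroxy group of compound 1, as all of the present reading of the chloro rests on compounds carrying the trifluoromethyl group.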